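The source may hold more compounds than are shown below. What is called first, only, known or untested is meant among the compounds shown, and "the series" means these compounds.

Series notes. In a functional assay on the whole organism for inhibition, with Cavia porcellus as the target, with stated times of 1 h and 10 min, at a dose of 1 mg/kg by the oral route (a lower number here means a weaker effect, a higher number a stronger effect of the compound at the dose given), compound 1 `Cc1c(F)cccc1CCCCOc1ccc(/C=C/c2cccc3c(CCCC(=O)O)cn(CC(=O)O)c23)cc1` gives 97% and compound 2 `O=C(O)CCCc1cn(CC(=O)O)c2c(/C=C/c3ccc(OCCCCOc4ccccc4)cc3)cccc12` gives 97%; the step of no change at the digits printed from compound 1 to compound 2 (within the scatter) shows that exchanging the aryl tail left the read-out unchanged. Compound 3 `Cc1c(CCCC(=O)O)c2cccc(/C=C/c3ccc(OCCCCc4c(F)ccc(F)c4F)cc3)c2n1CC(=O)O` gives 25%, the lowest of the three values, beyond the scatter below both compound 1 and compound 2. Compound 4 `O=C(O)CCCc1cn(CC(=O)O)c2c(/C=C/c3ccc(OCCCCc4c(F)ccc(F)c4F)cc3)cccc12` is not yet measured; it differs from compound 3 by hydrogen in place of methyl on an aromatic carbon. For the measured compounds named here, no measured step isolates this change, but compound 1 and compound 2 both lack that methyl and give high values, while the tail exchange in no change at the digits printed from compound 1 to compound 2 (within the scatter) was without effect. A rise is therefore expected, with a number 55 percentage points higher from compound 3 to compound 4 (beyond the scatter). For compound 4 the estimate is 80%, range 45% to 98%.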

Compound 4, a percentage reported as inhibition, in the whole organism at one dose (the size of the read-out at that dose, not a potency) in the Cavia porcellus assay: 94%
The estimate for compound 4 lay 14 percentage points below the measured number; low and high end bracket the measured number.
By their numbers in the Cavia porcellus assay, from the lowest: compound 3; then compounds 4, 1 and 2 (each within the scatter of the next).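

In the Cavia porcellus assay, hydrogen in place of methyl on this aromatic carbon, with nothing else changed, gives a number 69 percentage points higher from compound 3 to compound 4 (beyond the scatter), so this single position alone separates the low and high values. With hydrogen there, the Cavia porcellus assay shows a number 3 percentage points lower from compound 2 to compound 4 (within the scatter) and a number 3 percentage points lower from compound 1 to compound 4 (within the scatter), so the 2,3,6-trifluorophenyl tail fits the high group of values. In a physicochemical assay for permeability, using PAMPA, with a stated time of 4 h, at pH 6.2, tested at 50 uM (a higher number here means that the compound crosses the layer faster, a lower number that the compound crosses the layer more slowly), compound 3 gives 4.4 10^-6 cm/s and compound 4 gives 1.4 10^-6 cm/s and the same change moves the other way: the measured apparent permeability of compound 3, 4.4 10^-6 cm/s, and of compound 4, 1.4 10^-6 cm/s, a 3.1-fold lower number (0.50 log units; beyond the scatter)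

On these data alone, whether ethyl, chlorine or an amine on this carbon would lower the read-out as methyl does remains open. Also open, as far as these compounds go, is whether methyl has the same effect alongside the other two tails.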